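Acyl variation on the bridged diamine core

The source may report more compounds than this note shows. Statements on the series, on what has been measured and on what is new or still open speak of the compounds shown alone.

Measured so far:
compound 1 `CC(=O)N1CC2CC(C1)N2` — 5100 nM
compound 2 `CC(C)C(=O)N1CC2CC(C1)N2` — 19000 nM

Compound 2 `CC(C)C(=O)N1CC2CC(C1)N2` gives 19000 nM in an assay on SH-EP1 cells for agonist activity at Neuronal acetylcholine receptor; alpha4/beta2 (Homo sapiens), read by FLIPR and calcium flux (a higher number here means that more compound is needed for the effect, a lower number that less compound is needed), the higher of the two numbers recorded; compound 1 `CC(=O)N1CC2CC(C1)N2` gives 5100 nM in this assay. Among the measured compounds shown here, the only step in hand, a 3.7-fold higher number from compound 1 to compound 2 (0.57 log units; beyond the scatter), is modest but lies beyond the scatter.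

Compound 3 `O=C(C1CCC1)N1CC2CC(C1)N2` is not yet measured in this assay. It differs from compound 2 by cyclobutyl in place of isopropyl on a carbonyl carbon. The one measured step bears on this change in that both enlarge the group on the carbonyl carbon: from methyl to isopropyl the number rose by the step given above. Going on from isopropyl to cyclobutyl adds one carbon and closes a four-membered ring; the same direction of movement is expected, but a smaller one, since the change in size here is less than from methyl to isopropyl. The step from compound 2 to compound 3 is estimated at a 1.6-fold higher number from compound 2 to compound 3 (0.20 log units; within the scatter), possibly within the scatter. Compound 3 is therefore expected to give about 30000 nM in this assay, with a range of 12000 nM to 80000 nM.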

Compound 3, half-maximal effective concentration: 2900 nM
Compound 3: middle estimate off by 10-fold (1.01 log units), on the high side; measured number outside the range, below it.
By their numbers in this assay, from the lowest: compounds 3 and 1 (each within the scatter of the next); then compound 2.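

In this assay the size of the group on the carbonyl carbon does not set the number on its own: cyclobutyl in place of isopropyl gives a 6.6-fold lower number from compound 2 to compound 3 (0.82 log units; beyond the scatter) and so reverses the direction of a 3.7-fold higher number from compound 1 to compound 2 (0.57 log units; beyond the scatter) even though cyclobutyl has the larger heavy-atom count. Set against methyl, cyclobutyl gives a 1.8-fold lower number from compound 1 to compound 3 (0.25 log units; within the scatter) and so stands level with the acetyl compound within the scatter, which leaves compound 2 as the one compound of the three set apart from the others, and compound 3 goes against any trend that rises with heavy-atom count. Nothing at hand accounts for the gap between the closed four-membered ring and the open isopropyl group.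

Whether the ring itself or the removal of the isopropyl branch lies behind this step stays open, and a cyclopropyl or cyclopentyl group or a straight propyl chain on the same carbonyl carbon would help to separate the two readings. Also open, going by these compounds, is how this position responds to groups that are not pure carbon, such as an amine or an ether oxygen in the acyl part.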